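This account rests on a few compounds, and the source may have more. Where it says the series, first, only, none or still open, it means among the compounds named here.

Measured compounds:
- compound 1 `CN(C)CCNc1n[n+]([O-])c2ccccc2[n+]1[O-]` gives 50000000 nM
- compound 2 `COc1ccc2c(c1)[n+]([O-])c(NCCN(C)C)n[n+]2[O-]` gives 46000000 nM

In a physicochemical assay for solubility, in the presence of a further agent that is not named here (on this read-out lower numbers stand for lower solubility and higher numbers for higher solubility), compound 2 holds the lowest of the two numbers, with compound 1 as its nearest neighbour, the pair separated by a 1.1-fold lower number from compound 1 to compound 2 (0.04 log units; within the scatter). The next compound, compound 3 `CC(C)Oc1ccc2c(c1)[n+]([O-])c(NCCN(C)C)n[n+]2[O-]`, has not yet been measured in this assay. Its difference from compound 2 is isopropyl in place of methyl on an oxygen on an aromatic ring. Among the measured compounds shown here, only one measured step exists here, the move from compound 1 to compound 2, in which methoxy replaced hydrogen on an aromatic carbon, and that step stayed within the scatter. For the measured compounds named here, no measured step swaps one alkyl group for another on the ring oxygen, so the comparison is indirect. Going by the values given here, on the one step available, compound 3 is expected to give 30000000 nM, with a range from 8000000 nM to 60000000 nM. This estimate means a step of a 1.5-fold lower number from compound 2 to compound 3 (0.19 log units; within the scatter) from compound 2, expected to be small and, given the scatter, possibly not distinguishable from no change.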

Compound 3, solubility: > 51000000 nM
Compound 3: only a limit was reported; the forecaster's own chance of this, stated with the estimate: 5%; at least 1.7-fold (0.23 log units) between middle value and limit.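

In this assay compound 3 gives > 51000000 nM, which is a limit and not a number. Read as floors, the steps are an at least 1.1-fold higher number from compound 2 to compound 3 (0.04 log units; that floor lies within the scatter) and an at least 1.0-fold higher number from compound 1 to compound 3 (0.00 log units; that floor lies within the scatter); both floors lie within the scatter, so no order among the three compounds can be stated. What is new is that isopropyl in place of methyl on this oxygen, taking the group from 1 to 3 heavy atoms, brought no drop that can be read, whereas the earlier compounds showed only methoxy at this place, and the result rests on a limit: the limit of > 51000000 nM in this assay, at which 1 of the 3 values shown sits.

As far as these compounds go, how far the true value of compound 3 lies from its limit stays unknown, so the real size of the step cannot be told. Also open, from the compounds shown here alone, is whether a longer chain on this oxygen, or an amine or a carboxylic acid in its place, would keep the read-out in this range.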